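The source may hold more compounds than are shown below. What is called first, only, known or untested is meant among the compounds shown, and "the series" means these compounds.

Compound 3 `COc1cc(-c2nnc(SCc3ccccc3)n2-c2ccc(N(C)C)cc2)cc(OC)c1OC` stands highest of the two numbers in a functional assay on PC-3 cells (Homo sapiens) for inhibition, read by MTT assay, with a stated time of 48 h (on this read-out lower numbers stand for stronger inhibition and higher numbers for weaker inhibition), where compound 3 gives 55800 nM. Its nearest neighbour is compound 1 `COc1ccc(-n2c(SCc3ccccc3)nnc2-c2cc(OC)c(OC)c(OC)c2)cc1`, which in this assay gives 34100 nM, so that a 1.6-fold higher number from compound 1 to compound 3 (0.21 log units; within the scatter). Compound 2 `CCOC(=O)CSc1nnc(-c2cc(OC)c(OC)c(OC)c2)n1-c1ccc(OC)cc1` reaches only the limit of this assay, > 60000 nM. The change from compound 3 to compound 4 `COc1ccc(NC(=O)CSc2nnc(-c3cc(OC)c(OC)c(OC)c3)n2-c2ccc(N(C)C)cc2)cc1` is (4-methoxyphenyl)carbamoyl in place of phenyl on a saturated chain carbon bound to a sulfur. Among the compounds with values here, the one measured step at the same place is an at least 1.7-fold higher number from compound 1 to compound 2 (0.24 log units; that floor lies within the scatter), a step that ended at the limit of > 60000 nM in this assay, at which 1 of the 3 values shown sits. On that ground the expected step is a 1.5-fold higher number from compound 3 to compound 4 (0.18 log units; within the scatter), a higher number, quite possibly ending again at a limit rather than a figure. The estimate for compound 4 is 85000 nM, within a range from 40000 nM to 200000 nM.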

Compound 4, half-maximal inhibitory concentration: 56100 nM
Compound 4: the middle estimate sits 1.5-fold (0.18 log units) above what was measured; low and high end bracket the measured number.
By their numbers in this assay, from the lowest: compounds 1, 3 and 4 (each within the scatter of the next). At a limit, above all of these: compound 2.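

In this assay the exchange gives a 1.0-fold higher number from compound 3 to compound 4 (0.00 log units; within the scatter), so at this place (4-methoxyphenyl)carbamoyl cannot be told apart from phenyl. The one earlier step at this place ended at a limit, whereas compound 4 returns a figure, so a change on this saturated chain carbon bound to a sulfur need not end there: the limit of > 60000 nM in this assay, at which 1 of the 4 values shown sits.

As far as these compounds go, how a carboxylic acid or a simple amine at this place would read remains open. So does whether (4-methoxyphenyl)carbamoyl would read the same on the core of compound 1.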